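The compounds below may be only part of what the source reports. "The series", "measured", "known", "first", "only" and "open" are said of these compounds alone.

Measured so far in a functional assay on HCT-116 cells (Homo sapiens) for cytotoxicity, read by resazurin assay, with a stated time of 48 h; on this read-out higher numbers stand for an effect only at larger amounts of compound and lower numbers for an effect already at smaller amounts:
- compound 1 `O=C(Nc1ccc(Sc2nc3ccccc3s2)cc1)c1cc(Br)cc(Br)c1O`: 19000 nM
- compound 2 `O=C(Nc1ccc(Sc2nc3ccccc3s2)c(Cl)c1)c1cccc(Br)c1O`: 12000 nM
- compound 3 `COc1ccc(S(=O)(=O)Nc2ccc3oc(-c4ccc(NS(=O)(=O)c5cc(F)ccc5OC)cc4)nc3c2)cc1`: 15000 nM

The three numbers sit close together. Compound 3 lies among them: its number is within the scatter of the number of compound 2 and likewise within the scatter of the number of compound 1, so none of the three compounds can be separated from another on this read-out. Within the data shown here, no pair among them differs in one place only, so no single structural step is available to calibrate a change.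

Compound 4 `COc1ccc(S(=O)(=O)Nc2ccc3oc(-c4ccc(NC(=O)c5ccc(Cl)s5)cc4)nc3c2)cc1` is not yet measured. It differs from compound 3 as follows: a group of 8 heavy atoms (5 carbon, 1 oxygen, 1 sulfur, 1 chlorine; one five-membered aromatic ring with 1 hetero atom) in place of a group of 12 heavy atoms (7 carbon, 3 oxygen, 1 fluorine, 1 sulfur; one six-membered aromatic ring of carbon only), on a nitrogen on an aromatic ring The exchange is sizeable in count, yet the rest of the shared core stands unchanged, and all three measured compounds, across quite different groups, give numbers inside one scatter band. For compound 4 the expectation is therefore a step from compound 3 of no change at the digits printed from compound 3 to compound 4 (within the scatter), that is, no change beyond the scatter in either direction. On that basis compound 4 is estimated at 15000 nM, with a range from 5000 nM to 40000 nM.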

Compound 4, half-maximal effective concentration: 5400 nM
The estimate for compound 4 lay 2.8-fold (0.44 log units) above the measured number; measured number inside the range.
By their numbers in this assay, from the lowest: compound 4; then compounds 2, 3 and 1 (each within the scatter of the next).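

In this assay, the nitrogen on an aromatic ring proves to be a place where one exchange can move the number: putting (5-chlorothiophen-2-yl)carbonyl on it in place of the larger group gives a 2.8-fold lower number from compound 3 to compound 4 (0.44 log units; beyond the scatter), a modest step but beyond the scatter. The earlier compounds shown here offered no single-place step, so their shared band said nothing about whether this position responds to change. No available data bear on why the number moves here.

The whole group changes in this one step, so the part responsible stays unresolved: the chlorine, the thiophene ring or the carbonyl. On these data alone, whether a plain benzoyl group, an unsubstituted thiophen-2-ylcarbonyl group or an acetyl group on the same nitrogen would hold, extend or lose the step remains open.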